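The compounds below may be only part of what the source reports. "The series", "measured", "known", "first", "only" and "open" are said of these compounds alone.

Measured compounds:
- compound 1, `CCCS(=O)(=O)Nc1ccc(F)c(C(=O)c2n[nH]c3ncc(-c4ccc(F)cc4)cc23)c1F`: 2.1%
- compound 2, `CCCS(=O)(=O)Nc1ccc(F)c(C(=O)c2n[nH]c3ncc(-c4ccc(Cl)c(Cl)c4)cc23)c1F`: 45%

In an assay for binding affinity to dual specificity mitogen-activated protein kinase kinase 4 (Homo sapiens), read by KINOMEscan, tested at 100 nM (a lower number here means a stronger effect, a higher number a weaker effect of the compound at the concentration tested), compound 1 gives 2.1%, while compound 2 gives 45%. Compound 2 thus stands highest of the two numbers, that is, it shows the weaker effect at the concentration tested. Among the measured compounds shown here, the single step between them, a number 42.9 percentage points higher from compound 1 to compound 2 (beyond the scatter), is beyond the scatter and large.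

Compound 3, `CCCS(=O)(=O)Nc1ccc(F)c(C(=O)c2n[nH]c3ncc(-c4ccc([N+](=O)[O-])cc4)cc23)c1F`, is not yet measured in this assay. Its change from compound 2 is 4-nitrophenyl in place of 3,4-dichlorophenyl on an aromatic carbon. For the measured compounds named here, no measured step bears directly on this change: the only step available, a number 42.9 percentage points higher from compound 1 to compound 2 (beyond the scatter), shows that exchanging the aryl group at this position can move the read-out a long way, but it involves neither of the two groups that are swapped here. The direction for compound 3 is therefore open. Given that the two measured values frame a wide span, the estimate for compound 3 is placed between them, nearer the middle, as 20% with a range from 3% to 60%. This corresponds to an expected step of a number 25 percentage points lower from compound 2 to compound 3 (beyond the scatter), whose direction is uncertain.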

Compound 3, a percentage reported as activity, at one concentration (the size of the read-out at that concentration, not a potency): 4.2%
For compound 3 the middle estimate is 15.8 percentage points above the measured one, within the range that was stated.
By their numbers in this assay, from the lowest: compounds 1 and 3 (each within the scatter of the next); then compound 2.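

The step of a number 40.8 percentage points lower from compound 2 to compound 3 (beyond the scatter) in this assay shows that a substituted phenyl group at this position does not in itself bring the weaker effect seen with the 3,4-dichlorophenyl group. The step of a number 2.1 percentage points higher from compound 1 to compound 3 (within the scatter) adds that nitro in place of fluoro on this phenyl ring leaves the read-out within the scatter, so 4-nitrophenyl and 4-fluorophenyl cannot be told apart here, although the two groups differ in their atoms and in their count of hydrogen-bond acceptors. Among the three compounds shown, compound 2 alone stands apart, and its steps to compound 1 and compound 3 are both large.

Nothing available explains why the 3,4-dichlorophenyl group differs from the other two groups. As far as these compounds go, it remains open whether the change in compound 2 goes with chlorine itself or with having two substituents on the ring, a question that a 4-chlorophenyl or a 3-chlorophenyl group at this position would address, while an unsubstituted phenyl or a 4-aminophenyl group would show how far the read-out depends on the substituent at all.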